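Swapping an aryl ether for an aminopiperidine on the shared core

The compounds below may be only part of what the source reports. "The series", "measured", "known", "first", "only" and "open" are said of these compounds alone.

In a functional assay for inhibition of sodium/hydrogen exchanger (Oryctolagus cuniculus) (a higher number here means a weaker inhibitor, a lower number a stronger inhibitor), compound 2 `Cc1cc(Oc2ccc(Cl)cc2)c(S(C)(=O)=O)cc1C(=O)N=C(N)N` gives 13 nM, the lowest of the two numbers measured, and compound 1 `Cc1cc(Sc2ccc(Cl)cc2)c(S(C)(=O)=O)cc1C(=O)N=C(N)N` gives 19 nM. Among the compounds with values here, the only step measured, a 1.5-fold lower number from compound 1 to compound 2 (0.16 log units; within the scatter), lies within the scatter. Compound 3 `Cc1cc(N2CCC(N)CC2)c(S(C)(=O)=O)cc1C(=O)N=C(N)N` carries a different change: 4-aminopiperidin-1-yl in place of 4-chlorophenoxy on an aromatic carbon. Within the data shown here, no measured step resembles this exchange of an aromatic group for a non-aromatic ring with a basic nitrogen, so the prediction rests on little. A weaker inhibitor is expected, with a 6.2-fold higher number from compound 2 to compound 3 (0.79 log units; beyond the scatter) as the estimated step, so compound 3 is estimated at 80 nM in this assay, within a range of 15 nM to 500 nM.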

Compound 3, half-maximal inhibitory concentration: 9.8 nM
The estimate for compound 3 lay 8.2-fold (0.91 log units) above the measured number, outside the stated range (below it).
By their numbers in this assay, from the lowest: compounds 3, 2 and 1 (each within the scatter of the next).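

In this assay the position ortho to the methylsulfonyl group accepts 4-aminopiperidin-1-yl, a non-aromatic ring, in place of 4-chlorophenoxy with no change beyond the scatter (a 1.3-fold lower number from compound 2 to compound 3 (0.12 log units; within the scatter)). The same holds against (4-chlorophenyl)sulfanyl (a 1.9-fold lower number from compound 1 to compound 3 (0.29 log units; within the scatter)), so among these three compounds an aromatic ring at this position is not needed to stay at this level. No evidence here accounts for this. As far as these compounds go, it remains open what the primary amine of the piperidine contributes: plain piperidine, 4-hydroxypiperidine or an open-chain aminoalkyl group would test that.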